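Swapping 3,4-difluorophenyl for 4-(dimethylamino)phenyl on the shared core

The compounds below may be only part of what the source reports. "The series", "measured", "known", "first", "only" and "open" are said of these compounds alone.

Compound 1 `COc1ccc(S(=O)(=O)N2CCc3cccc(-c4ccc(F)nc4)c32)cc1` gives 143 nM
Compound 2 `COc1ccc(S(=O)(=O)N2CCc3cccc(-c4ccco4)c32)cc1` gives 82 nM
Compound 3 `COc1ccc(S(=O)(=O)N2CCc3cccc(-c4ccc(F)c(F)c4)c32)cc1` gives 45 nM

These values come from a functional assay on KB cells (Homo sapiens) for inhibition, with a stated time of 72 h; a higher number here means a weaker inhibitor, a lower number a stronger inhibitor. Compound 3 sits at the low end of the three numbers, but only one of its gaps is clear: a 3.2-fold lower number from compound 1 to compound 3 (0.50 log units; beyond the scatter). The other gap is smaller, a 1.8-fold lower number from compound 2 to compound 3 (0.26 log units; within the scatter), and does not separate the pair.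

Compound 4 `COc1ccc(S(=O)(=O)N2CCc3cccc(-c4ccc(N(C)C)cc4)c32)cc1` has not yet been measured. Its change from compound 3 falls at the same aromatic carbon: 4-(dimethylamino)phenyl in place of 3,4-difluorophenyl on an aromatic carbon. All three measured steps are exchanges at this carbon. Beside the two above there is a 1.7-fold lower number from compound 1 to compound 2 (0.24 log units; within the scatter). Within the data shown here, the largest of them is only modest, and none involves a dimethylamino group, so the data offer no direct precedent for this one. A step of similar or smaller size is therefore expected in this assay, with no firm direction. The estimated change is a 1.3-fold higher number from compound 3 to compound 4 (0.12 log units; within the scatter), so no shift beyond the scatter is expected. For compound 4 the expected value is 60 nM, with an estimated range from 20 nM to 180 nM.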

Compound 4, half-maximal inhibitory concentration: 539 nM
Compound 4: middle estimate off by 9.0-fold (0.95 log units), on the low side; measured number outside the range, above it.
By their numbers in this assay, from the lowest: compounds 3, 2 and 1 (each within the scatter of the next, the first and the last beyond it); then compound 4.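

In this assay, among these compounds, this aromatic carbon proves far less permissive than the earlier exchanges suggested: those spanned no more than a modest step, whereas 4-(dimethylamino)phenyl in place of 3,4-difluorophenyl gives a 12-fold higher number from compound 3 to compound 4 (1.08 log units; beyond the scatter), the only large step in the set. The weakening is not specific to that one comparison, since the same group also separates clearly from the furan-2-yl and 6-fluoropyridin-3-yl groups, with a 6.6-fold higher number from compound 2 to compound 4 (0.82 log units; beyond the scatter) and a 3.8-fold higher number from compound 1 to compound 4 (0.58 log units; beyond the scatter). Thus, among the four groups shown at this carbon, 4-(dimethylamino)phenyl alone stands clearly apart from all the others, and no measurement offered here accounts for the rise.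

The step from compound 3 removes two fluorines and adds a dimethylamino group at once, so the compounds shown cannot separate the effect of one change from that of the other. Going by these compounds, whether an unsubstituted phenyl, or a phenyl carrying a primary amine or a methoxy group, would fall with compound 3 or with compound 4 remains open.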